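The compounds below may be only part of what the source reports. "The series", "measured", "known", "first", "only" and "open" are said of these compounds alone.

Compound 2 `CC(C)Oc1cc(-c2cncc(-c3cnn(C(C)C)c3)c2)ccc1C(N)=O` stands at the strong end of the three compounds measured in an assay on cells for inhibition of MAP kinase-interacting serine/threonine-protein kinase 1 (Homo sapiens), read by mobility shift assay, with stated times of 10 min and 60 min, in the presence of a further agent that is not named here; on this read-out lower numbers stand for stronger inhibition and higher numbers for weaker inhibition: compound 2 gives 85 nM. Compound 1 `CCOc1cc(-c2cccnc2)ccc1C(N)=O`, which carries a smaller substituent pattern on the shared core, gives 2200 nM in this assay, a number beyond the scatter above that of compound 2. Compound 3 `CC(=O)c1cncc(-c2ccc(C(N)=O)cc2)c1` gives 8000 nM, again well beyond the scatter above compound 2, so compound 2 is the most potent of the three.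

Compound 4 `CC(C)Oc1cc(-c2cncc(-c3cnn(C)c3)c2)ccc1C(N)=O` differs from compound 2 in one place: methyl in place of isopropyl on an aromatic nitrogen. Within the data shown here, no pair among the measured compounds shows this kind of change, so the size of the step is not anchored by any measured example. A change of this sort, trimming a small alkyl group at a ring position remote from the amide, is expected to move the number only modestly, if at all beyond the scatter, with the more likely direction being a slight weakening. The step of a 1.5-fold higher number from compound 2 to compound 4 (0.18 log units; within the scatter) is therefore expected to be small. Compound 4 is estimated to give 130 nM, within a range from 50 nM to 350 nM.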

Compound 4, half-maximal inhibitory concentration: 400 nM
Compound 4: the middle estimate sits 3.1-fold (0.49 log units) below what was measured; the measured number lies above the stated range.
By their numbers in this assay, from the lowest: compound 2; then compound 4; then compound 1; then compound 3.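

Going from 1-isopropyl-1H-pyrazol-4-yl to 1-methyl-1H-pyrazol-4-yl gives a 4.7-fold higher number from compound 2 to compound 4 (0.67 log units; beyond the scatter), so in this assay the number responds to which alkyl group sits on this aromatic nitrogen. Among these compounds, this is the first comparison in the set that changes only one place, and it shows that isopropyl gives the lower number of these two groups with the rest of compound 2 left unchanged. Nothing measured here accounts for the step, which stands as an observation about this one pair.

Still open, going by these compounds, is how the number responds to other groups on this nitrogen, such as a cyclopentyl group, a longer chain such as n-butyl, or a chain ending in an amine. On these data alone, it is also open whether the step between isopropyl and methyl keeps its size when other parts of the compound change.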